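A few compounds are considered here, and "the series" means these few. Any claim that something is new, unique, unknown or untested is made for them only; others in the source may bear on it.

Measured in a functional assay on the whole organism for positive allosteric modulation, with Mus musculus as the target; on this read-out lower numbers stand for an effect already at smaller amounts and higher numbers for an effect only at larger amounts of compound:
compound 1 `CCC(=O)N(c1ccc(OC)cc1)C1CCCC1N(C)C`: 30 mg/kg; 30 mg/kg (2 entries), found twice
compound 2 `CCC(=O)N(c1ccc(F)cc1)C1CCCC1N(C)C`: 5 mg/kg

Compound 2 stands at the lower end of this short series: compound 2 acts at 5 mg/kg, whereas compound 1 needs 30 mg/kg; 30 mg/kg (2 entries). Within the data shown here, with only two compounds measured, the data offer little to go on.

Compound 3 `CCC(=O)N(c1ccc(Br)cc1)C1CCCC1N(C)C` keeps the shared core and alters one substituent: bromo in place of fluoro on an aromatic carbon. This places bromo in place of fluoro on an aromatic carbon, para to a large group. Among the measured compounds shown here, no measured pair shows this exchange directly, so the expectation in this assay is tentative. A small rise in dose, probably within the usual scatter, is expected: a 1.6-fold higher number from compound 2 to compound 3 (0.20 log units; within the scatter). For compound 3 the estimated value is 8 mg/kg, with an expected range of 2.5 mg/kg to 30 mg/kg.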

Compound 3, dose for half-maximal effect: 2 mg/kg
Compound 3: the middle estimate sits 4.0-fold (0.60 log units) above what was measured; measured number below the stated range.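

Bromo in place of fluoro on an aromatic carbon, para to a large group, gives a 2.5-fold lower number from compound 2 to compound 3 (0.40 log units; beyond the scatter) in this assay and so goes further than the earlier contrast between methoxy and fluoro. It shows that the read-out at this position can still shift beyond the usual scatter when one single-atom substituent replaces another, with no change in the counted hydrogen-bond donors, acceptors or net charge. Nothing available explains this step.

On these data alone, what chloro, trifluoromethyl or an amine at this same place would give remains open. As far as these compounds go, it is also open whether bromo in place of fluoro would give a similar step with a longer chain on the carbonyl of the shared core.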